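Swapping 4-methoxybenzyl for propyl on the shared core

A few compounds are considered here, and "the series" means these few. Any claim that something is new, unique, unknown or untested is made for them only; others in the source may bear on it.

Measured in a functional assay on cells (Platelet, Homo sapiens) for inhibition; a lower number here means a stronger inhibitor, a higher number a weaker inhibitor:
- Compound 1 `CCOC(=O)c1ccc(-c2nn(Cc3ccccc3OC)c3ccccc23)cc1`: > 10000 nM
- Compound 2 `CCOC(=O)c1ccc(-c2nn(Cc3cccc(OC)c3)c3ccccc23)cc1`: > 10000 nM
- Compound 3 `CCOC(=O)c1ccc(-c2nn(Cc3ccc(OC)cc3)c3ccccc23)cc1`: > 10000 nM

All three readings are limits, not numbers, as the limit of > 10000 nM in this assay, at which 3 of the 3 values shown sit, shows. Compound 3 stands at > 10000 nM, which is a limit.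

The next compound, compound 4 `CCCn1nc(-c2ccc(C(=O)OCC)cc2)c2ccccc21`, differs from compound 3 by ethyl in place of 4-methoxyphenyl on a saturated chain carbon bound to an aromatic nitrogen. In words, this is ethyl in place of 4-methoxyphenyl on a saturated chain carbon bound to an aromatic nitrogen, or 4-methoxybenzyl to propyl when cut one bond further out.

The nearest evidence comes from changes at this same place: a step that the two limits leave unreadable from compound 1 to compound 2, a step that the two limits leave unreadable from compound 1 to compound 3 and a step that the two limits leave unreadable from compound 2 to compound 3. None of them has a readable size, and none swaps the ring for a plain chain. They therefore offer no size or direction to carry over, and no clear change is expected in this assay.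

The expected step is a step that the limit leaves unreadable from compound 3 to compound 4. For compound 4 the estimated value is 15000 nM, with an expected range from 4000 nM to 50000 nM.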

Compound 4, half-maximal inhibitory concentration: > 10000 nM
Compound 4 gave a limit, no number (the forecaster's own chance of this, stated with the estimate: 75%); the middle value lies beyond the limit too.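

Compound 4 gives > 10000 nM in this assay, which is a limit, not a number. No step from compound 1, compound 2 or compound 3 to compound 4 can be read, since every reading here is a limit: the limit of > 10000 nM in this assay, at which 4 of the 4 values shown sit.

The compounds shown leave open whether any group at this place on the shared core gives a measurable inhibition.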